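This account rests on a few compounds, and the source may have more. Where it says the series, first, only, none or still open, it means among the compounds named here.

Two compounds with the shared core of compound 1 `CSc1nc(=O)ccn1[C@@H]1O[C@H](COP(=O)(O)OP(=O)(O)O)[C@@H](O)[C@H]1O` have been characterised in an in vitro functional assay on 1321-N1 cells for agonist activity at P2Y purinoceptor 2 (Homo sapiens), read by scintillation proximity assay and inositol phosphate accumulation; a lower number here means that less compound is needed, a higher number that more compound is needed for the effect. In this assay compound 1 gives 523 nM. Going by the values given here, compound 2 `O=c1ccn([C@@H]2O[C@H](COP(=O)(O)OP(=O)(O)O)[C@@H](O)[C@H]2O)c(SCc2ccccc2)n1` carries a benzyl group on the sulfur instead of a methyl, and in this assay compound 2 gives 6200 nM, the highest number of the two; the only measured step, a 12-fold higher number from compound 1 to compound 2 (1.07 log units; beyond the scatter), is large and lies beyond the scatter.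

Compound 3 `CNc1nc(=O)ccn1[C@@H]1O[C@H](COP(=O)(O)OP(=O)(O)O)[C@@H](O)[C@H]1O` is the next step from compound 2. The change is methylamino in place of benzylsulfanyl on an aromatic carbon. Among the compounds with values here, the one step that bears on it runs in the opposite direction: taking away the phenyl on the saturated chain carbon bound to sulfur undid most of the benzyl effect seen in the step to compound 2, and the group that enters is as small as the methylsulfanyl of compound 1, though it brings a nitrogen with a hydrogen-bond donor instead of a sulfur. The step is therefore expected to be a clearly lower number, an 8.9-fold lower number from compound 2 to compound 3 (0.95 log units; beyond the scatter), bringing compound 3 close to compound 1. Compound 3 is estimated at 700 nM, with a range from 200 nM to 2500 nM.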

Compound 3, half-maximal effective concentration: 7600 nM
Compound 3: the middle estimate sits 11-fold (1.04 log units) below what was measured; measured number outside the range, above it.
By their numbers in this assay, from the lowest: compound 1; then compounds 2 and 3 (each within the scatter of the next).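

In this assay, methylamino in place of benzylsulfanyl on this aromatic carbon gives a 1.2-fold higher number from compound 2 to compound 3 (0.09 log units; within the scatter) and so leaves the number within the scatter, although the group that enters has no ring and far fewer heavy atoms than the one that leaves. Going by these compounds alone, measured against the methylsulfanyl of compound 1, methylamino gives a large step, a 15-fold higher number from compound 1 to compound 3 (1.16 log units; beyond the scatter), and this is the first sign that a small group at this position does not by itself keep the number low. Among the three compounds, only compound 1 stands apart, so the position distinguishes methylsulfanyl from methylamino, while methylamino and benzylsulfanyl, two very different groups, cannot be told apart here.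

The compounds shown leave open whether the sulfur link itself sets the lower number, which a methoxy group or an ethylsulfanyl group at the same carbon would help to settle. They also leave open whether the hydrogen on the nitrogen matters, as a comparison of methylamino with dimethylamino would show. Nothing given here explains why methylsulfanyl and methylamino differ in this way.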